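This account rests on a few compounds, and the source may have more. Where it says the series, first, only, none or still open, it means among the compounds named here.

Measured so far in a functional assay on PC-3 cells (Homo sapiens) for inhibition; on this read-out lower numbers stand for stronger inhibition and higher numbers for weaker inhibition:
compound 1 `COc1cc2nc(N3CCN(S(=O)(=O)c4ccc(C(F)(F)F)cc4)CC3)nc(N)c2cc1OC`, 27000 nM
compound 2 `COc1cc2nc(N3CCN(S(=O)(=O)c4ccc(C(C)(C)C)cc4)CC3)nc(N)c2cc1OC`, 4100 nM
compound 3 `COc1cc2nc(N3CCN(S(=O)(=O)c4ccc(C(=O)O)cc4)CC3)nc(N)c2cc1OC`, 53000 nM

Compound 3 gives the highest of the three numbers. The nearer gap is a 2.0-fold higher number from compound 1 to compound 3 (0.29 log units; within the scatter), within the scatter, whereas compound 2 stands apart by a 13-fold higher number from compound 2 to compound 3 (1.11 log units; beyond the scatter). Compound 4 `COc1cc2nc(N3CCN(S(=O)(=O)c4ccc5ccccc5c4)CC3)nc(N)c2cc1OC` differs from compound 3 in one place: naphthalen-2-yl in place of 4-carboxyphenyl on a sulfonyl sulfur. The step bearing most directly on this change is a 13-fold higher number from compound 2 to compound 3 (1.11 log units; beyond the scatter), in which the carboxy group entered in place of tert-butyl; a 6.6-fold lower number from compound 1 to compound 2 (0.82 log units; beyond the scatter) also points to lower numbers for a carbon-only group. A large step to a lower number in this assay is therefore expected for compound 4. Compound 4 is estimated at 5000 nM, expected to lie between 1500 nM and 20000 nM. The step this estimate implies is expected to be an 11-fold lower number from compound 3 to compound 4 (1.03 log units; beyond the scatter).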

Compound 4, half-maximal inhibitory concentration: 15000 nM
For compound 4 the middle estimate is 3.0-fold (0.48 log units) below the measured one, and the stated range covers the measured number.
By their numbers in this assay, from the lowest: compound 2; then compounds 4, 1 and 3 (each within the scatter of the next, the first and the last beyond it).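

In this assay, naphthalen-2-yl on the sulfonyl sulfur gives a 3.5-fold lower number from compound 3 to compound 4 (0.55 log units; beyond the scatter), a step beyond the scatter that the trifluoromethyl compound did not show against the carboxy compound. It does not match the 4-(tert-butyl)phenyl group, with a 3.7-fold higher number from compound 2 to compound 4 (0.56 log units; beyond the scatter), while a 1.8-fold lower number from compound 1 to compound 4 (0.26 log units; within the scatter) leaves naphthalen-2-yl and 4-(trifluoromethyl)phenyl within the scatter of each other. No supporting data explain these differences. As far as these compounds go, it remains open whether an amine or a longer alkyl chain on the phenyl ring would give a lower number than the tert-butyl group does.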